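Removing One Methoxy Group: What to Expect for Compound 3

The source may report more compounds than this note shows. Statements on the series, on what has been measured and on what is new or still open speak of the compounds shown alone.

Compound 1 `COc1ccc(-c2cc(/C=C/C(=O)c3ccc(N)cc3)[nH]n2)cc1` and compound 2 `COc1cc(-c2cc(/C=C/C(=O)c3ccc(N)cc3)[nH]n2)cc(OC)c1OC` share a core and differ only in the methoxy pattern on one of their rings. In a functional assay on K562 cells (Homo sapiens) for inhibition, read by sulforhodamine B assay, with a stated time of 48 h (on this read-out higher numbers stand for lower toxicity in this test and lower numbers for higher toxicity in this test), compound 1 gives 69700 nM. In this assay compound 2 gives only a limit, > 100000 nM, and no number. That reading sits at the limit of > 100000 nM in this assay, at which 1 of the 2 values shown sits, so compound 2 stands at the edge of what the test reports. Compound 3 `COc1ccc(-c2cc(/C=C/C(=O)c3ccc(N)cc3)[nH]n2)cc1OC` has not yet been measured; it differs from compound 2 by hydrogen in place of methoxy on an aromatic carbon, and so stands between compound 1 and compound 2 in structure. Compound 1 gives 69700 nM. Compound 2 gives only a limit, and so the two known points leave little room for a step beyond the scatter in either direction. The step is expected to be an at least 1.1-fold lower number from compound 2 to compound 3 (0.07 log units; that floor lies within the scatter), within the scatter. Compound 3 is estimated at 85000 nM, in a range of 40000 nM to 180000 nM, with a real chance that the assay again returns only a limit.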

Compound 3, concentration lethal to 50% of the cells: > 100000 nM
Compound 3 ended at the assay's limit (the forecaster's own chance of this, stated with the estimate: 45%); at least 1.1-fold (0.07 log units) between middle value and limit.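

In this assay compound 3 gives > 100000 nM, which is a limit of the assay and not a number. With methoxy in place of hydrogen on an aromatic carbon, the result is an at least 1.4-fold higher number from compound 1 to compound 3 (0.15 log units; that floor lies within the scatter), so even this single change reaches the limit, though the printed floor of the step does not pass the usual scatter. Hydrogen in place of methoxy at this carbon, ortho to a methoxy group, does not bring compound 2 back to a readable number, and the step between those two limits cannot be read: the limit of > 100000 nM in this assay, at which 2 of the 3 values shown sit.

Going by these compounds, how far compound 2 and compound 3 lie past the limit remains open. On these data alone, it is also open whether a hydroxyl group, a fluorine atom or an amine on this aromatic carbon would give a readable number in this assay.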